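A few compounds are considered here, and "the series" means these few. Any claim that something is new, unique, unknown or untested is made for them only; others in the source may bear on it.

Measured so far in a functional assay on PC-3 cells (Homo sapiens) for cytotoxicity, read by MTT assay; a lower number here means a stronger inhibitor, a higher number a weaker inhibitor:
- compound 1 `Oc1ccc(CN(Cc2ccccc2C(F)(F)F)Cc2ccc(O)c3ncccc23)c2cccnc12`: 179 nM
- compound 2 `Oc1ccc(CN(Cc2cccc(C(F)(F)F)c2)Cc2ccc(O)c3ncccc23)c2cccnc12`: 37 nM

Among the measured compounds shown here, of these two, compound 2 has the lower number, at 37 nM, and the only other number belongs to compound 1, at 179 nM.

Next is compound 3 `Oc1ccc(CN(Cc2cc(C(F)(F)F)cc(C(F)(F)F)c2)Cc2ccc(O)c3ncccc23)c2cccnc12`, not yet measured in this assay. Its difference from compound 2 is trifluoromethyl in place of hydrogen on an aromatic carbon. The new trifluoromethyl sits on an aromatic carbon, meta to a trifluoromethyl group.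

For the measured compounds named here, only one measured step bears on this: a 4.8-fold lower number from compound 1 to compound 2 (0.68 log units; beyond the scatter), with 3-(trifluoromethyl)phenyl in place of 2-(trifluoromethyl)phenyl. That modest step moves a group and adds none, so it shows that the number can shift with the position of the trifluoromethyl group, but it gives no direction for a second one. Going by the values given here, no measured compound carries two such groups. A step beyond the scatter is therefore not expected in either direction, though one of similar size remains possible.

The estimate for compound 3 is an expected 35 nM, within an expected range of 11 nM to 110 nM. The expected change is a 1.1-fold lower number from compound 2 to compound 3 (0.02 log units; within the scatter).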

Compound 3, half-maximal inhibitory concentration: 71 nM
Beside the measured number, compound 3's estimate is 2.0-fold (0.31 log units) below it, within the range that was stated.
By their numbers in this assay, from the lowest: compounds 2 and 3 (each within the scatter of the next); then compound 1.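

The added trifluoromethyl, on an aromatic carbon meta to a trifluoromethyl group, gives a 1.9-fold higher number from compound 2 to compound 3 (0.28 log units; within the scatter) in this assay, so this change does not separate compound 3 from compound 2. Among the compounds shown here, this is the first reading of a group added to this ring rather than moved around it, and it contrasts with the shift of the single trifluoromethyl group, a 4.8-fold lower number from compound 1 to compound 2 (0.68 log units; beyond the scatter), which lies beyond the scatter. For the compounds shown here, the measured compounds therefore show a clear dependence on where the single group sits, but no such dependence on the presence of a second group at this position, and nothing at hand explains either result.

Still open, from the compounds shown here alone, is how a smaller or different group on this same aromatic carbon, such as a methoxy group, a chlorine atom or a carboxylic acid, would read in this assay against the trifluoromethyl of compound 3. Also open is the plain phenyl ring with no trifluoromethyl at all, since none of the compounds shown gives that reference point for the first group.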